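Removing a Hexyl Stretch from the Sulfonyl Chain

This account rests on a few compounds, and the source may have more. Where it says the series, first, only, none or still open, it means among the compounds named here.

Of the compounds shown here, two with the same core have been measured in a physicochemical assay for acid dissociation. Compound 1 `CCCCCCCCS(=O)(=O)c1ccc(O)c(C(=O)Nc2ccc(C(F)(F)F)cc2)c1` gives 6.2 in this assay, and compound 2 `CCCCCCCCCCCCS(=O)(=O)c1ccc(O)c(C(=O)Nc2ccc(C(F)(F)F)cc2)c1` gives 6.2 there, which places compound 2 level with compound 1 at the digits available.

The next compound, compound 3 `CCCCCCS(=O)(=O)c1ccc(O)c(C(=O)Nc2ccc(C(F)(F)F)cc2)c1`, comes from compound 2 by one change: hydrogen in place of hexyl on a saturated chain carbon, six bonds along the chain from a sulfonyl sulfur. In words, this is hydrogen in place of hexyl on a saturated chain carbon, six bonds along the chain from a sulfonyl sulfur.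

Among the measured compounds shown here, only one measured step bears on this change, namely no change at the digits printed from compound 1 to compound 2 (within the scatter). That step put butyl in place of hydrogen on a saturated chain carbon, eight bonds along the chain from a sulfonyl sulfur. For the measured compounds named here, no measured step covers the place six bonds along, so the comparison is indirect. Going by no change at the digits printed from compound 1 to compound 2 (within the scatter), no step beyond the scatter is expected in this assay, and a higher read-out is expected no more than a lower one. The expected change is no change at the digits printed from compound 2 to compound 3 (within the scatter). For compound 3 the estimated value is 6.2, with an expected range from 5.9 to 6.5.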

Compound 3, acid dissociation constant: 6.2
Compound 3: the middle estimate sits on the measured number at the digits printed, within the range that was stated.
By their numbers in this assay, from the lowest: compounds 1, 2 and 3 (each within the scatter of the next).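

In this assay the change at this place gives no change at the digits printed from compound 2 to compound 3 (within the scatter) and so turns an indirect reading from the earlier step, eight bonds along the chain, into a measured result for the place six bonds along the chain from a sulfonyl sulfur. The second new step reaches the same place with a smaller group, hydrogen in place of ethyl, and gives no change at the digits printed from compound 1 to compound 3 (within the scatter) so that both hexyl and ethyl can give way to hydrogen here with the read-out remaining within the scatter, and the octyl, dodecyl and hexyl chains of compound 1, compound 2 and compound 3 are not told apart by this assay. No measurement offered here gives a reason for this result.

The compounds shown leave open whether the read-out holds for a chain shorter than hexyl, such as ethyl or methyl on the sulfonyl sulfur, or for a chain that ends in a carboxylic acid or an amine. They also leave open what a nitrile would do in place of the trifluoromethyl group, since that group is common to all three compounds.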